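The source may hold more compounds than are shown below. What is called first, only, known or untested is meant among the compounds shown, and "the series" means these compounds.

Compound 1 `N[C@@H](CCC(=O)OC[C@H]1O[C@@H](n2cc(F)c(=O)[nH]c2=O)C[C@@H]1OC(=O)CC[C@H](N)C(=O)O)C(=O)O`: 0.352 h
Compound 2 `CC(C)[C@H](N)C(=O)OC[C@H]1O[C@@H](n2cc(F)c(=O)[nH]c2=O)C[C@@H]1O`: 0.255 h

Within the data shown here, in an ADME assay on tissue (MDA-MB-231 cells, Homo sapiens) for pharmacokinetics (a higher number here means that the compound lasts longer, a lower number that the compound disappears faster), compound 1 at 0.352 h and compound 2 at 0.255 h lie within the usual scatter of each other, so compound 1 stands level with the only other measured compound. Compound 3 `N[C@@H](CCC(=O)O[C@H]1C[C@H](n2cc(F)c(=O)[nH]c2=O)O[C@@H]1CO)C(=O)O` differs from compound 1 by one change: hydrogen in place of (3-amino-3-carboxypropyl)carbonyl on an oxygen on a saturated carbon. Among the measured compounds shown here, no measured pair shows this change alone. Compound 2, which carries one amino acid ester rather than two, gives 0.255 h, so no step beyond the scatter is expected in this assay. The expected change is a 1.2-fold lower number from compound 1 to compound 3 (0.07 log units; within the scatter). The estimated half-life of compound 3 is 0.3 h, with an expected range from 0.16 h to 0.55 h.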

Compound 3, half-life: 0.138 h
The estimate for compound 3 lay 2.2-fold (0.34 log units) above the measured number; the measured number lies below the stated range.
By their numbers in this assay, from the lowest: compounds 3, 2 and 1 (each within the scatter of the next, the first and the last beyond it).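

In this assay, hydrogen in place of (3-amino-3-carboxypropyl)carbonyl, which turns the (((3-amino-3-carboxypropyl)carbonyl)oxy)methyl group into hydroxymethyl, gives a 2.6-fold lower number from compound 1 to compound 3 (0.41 log units; beyond the scatter). This single change therefore moves the number beyond the scatter, so the group at this oxygen counts in this assay. Nothing at hand explains the step. From the compounds shown here alone, whether the matching group on the other oxygen counts to the same degree stays open. So does whether an acetyl group or a longer chain at this oxygen would keep the number at the level of compound 1.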